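The source may hold more compounds than are shown below. What is called first, only, known or untested is meant among the compounds shown, and "the series" means these compounds.

Compound 1 `C#CCOC(=O)C[C@@H]1C(C(=O)OC)=CO[C@@H](O[C@@H]2O[C@H](COC(C)=O)[C@@H](OC(C)=O)[C@H](OC(C)=O)[C@H]2OC(C)=O)/C1=C/C` and compound 2 `C/C=C1/[C@H](O[C@@H]2O[C@H](COC(C)=O)[C@@H](OC(C)=O)[C@H](OC(C)=O)[C@H]2OC(C)=O)OC=C(C(=O)OC)[C@H]1CC(=O)O` share the peracetylated sugar, while compound 3 `C/C=C1/[C@H](O[C@@H]2O[C@H](CO)[C@@H](O)[C@H](O)[C@H]2O)OC=C(C(=O)OC)[C@H]1CC(=O)OCCC1CCCCC1` carries the free sugar. In a functional assay on SK-BR-3 cells (Homo sapiens) for antiproliferative activity, read by MTT assay, with a stated time of 72 h (on this read-out higher numbers stand for weaker inhibition and lower numbers for stronger inhibition), compound 1 gives > 15000 nM, which is a limit of the assay and not a number. Compound 2 likewise gives > 15000 nM in this assay, again a limit. The step from compound 1 to compound 2, a step that the two limits leave unreadable from compound 1 to compound 2, therefore cannot be read, since both ends sit at the limit of > 15000 nM in this assay, at which 2 of the 3 values shown sit. Compound 3 gives 2000 nM in this assay and is the only compound shown with a number rather than a limit.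

Compound 4 `C/C=C1/[C@H](O[C@@H]2O[C@H](CO)[C@@H](O)[C@H](O)[C@H]2O)OC=C(C(=O)OC)[C@H]1CC(=O)OCc1ccccc1` differs from compound 3 by phenyl in place of cyclohexylmethyl on a saturated chain carbon bound to an oxygen next to a carbonyl group. No measured step touches this place: the one step shown, between compound 1 and compound 2, concerns a different position and is unreadable in any case. With nothing to anchor a direction, the step from compound 3 to compound 4 is expected to stay within scatter, no change at the digits printed from compound 3 to compound 4 (within the scatter). Compound 4 is thus estimated at 2000 nM in this assay, within a range from 700 nM to 6000 nM.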

Compound 4, half-maximal inhibitory concentration: > 15000 nM
Compound 4: only a limit was reported; the forecaster's own chance of this, stated with the estimate: 15%; middle value at least 7.5-fold (0.87 log units) away from the limit.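

In this assay, going by these compounds alone, this place proves sensitive: phenyl in place of cyclohexylmethyl gives an at least 7.5-fold higher number from compound 3 to compound 4 (0.87 log units; beyond the scatter), whereas the one earlier step could not be read. With the free sugar held constant, this is the first readable step among the compounds shown, although its full size stays open as compound 4 reports only a limit. Compound 3 is now the only compound with a number rather than a limit: the limit of > 15000 nM in this assay, at which 3 of the 4 values shown sit.

The change from 2-cyclohexylethyl to benzyl alters both the ring and the chain, and the compounds shown do not separate the two. Going by these compounds, how a 2-phenylethyl group, or a cyclohexyl ring bearing an amine, would read in this assay remains open.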